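Amide aryl substituent swap: methoxy to chloro

The compounds below may be only part of what the source reports. "The series", "measured", "known", "first", "only" and "open" are said of these compounds alone.

In a functional assay on MCF7 cells (Homo sapiens) for inhibition, read by sulforhodamine B assay, with a stated time of 24 h (on this read-out lower numbers stand for stronger inhibition of growth and higher numbers for weaker inhibition of growth), compound 1 `CCOC(=O)C1=C(C)NC(=O)NC1c1cn(-c2ccccc2)nc1-c1ccc(Cl)cc1` gives 68800 nM. Compound 2 `CC1=C(C(=O)Nc2ccccc2)C(c2cn(-c3ccccc3)nc2-c2ccc(Cl)cc2)NC(=O)N1` gives 65500 nM in this assay, and compound 3 `COc1ccc(NC(=O)C2=C(C)NC(=O)NC2c2cn(-c3ccccc3)nc2-c2ccc(Cl)cc2)cc1` gives 69700 nM. All three numbers sit within the scatter of one another, so compound 3 stands alongside compounds 1 and 2 with no separation beyond the scatter to either.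

Compound 4 `CC1=C(C(=O)Nc2ccc(Cl)cc2)C(c2cn(-c3ccccc3)nc2-c2ccc(Cl)cc2)NC(=O)N1` differs from compound 3 in one place: chloro in place of methoxy on an aromatic carbon. Among the compounds with values here, no measured step exchanges methoxy for chloro on this ring. Within the data shown here, the steps that bear on the question are those altering the same carbonyl substituent, a 1.1-fold lower number from compound 1 to compound 2 (0.02 log units; within the scatter) and a 1.0-fold higher number from compound 1 to compound 3 (0.01 log units; within the scatter), together with the substitution on the aryl ring of the amide, a 1.1-fold higher number from compound 2 to compound 3 (0.03 log units; within the scatter); each was within the scatter, and the three together suggest the amide aryl portion carries little weight in this assay on the compounds seen so far. The expectation is therefore no step beyond the scatter in either direction, a 1.0-fold lower number from compound 3 to compound 4 (0.01 log units; within the scatter). Compound 4 is estimated at 68000 nM, with a range from 30000 nM to 150000 nM.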

Compound 4, concentration for 50% growth inhibition: 56900 nM
Estimate against measurement, compound 4: 1.2-fold (0.08 log units) above, and the stated range covers the measured number.
By their numbers in this assay, from the lowest: compounds 4, 2, 1 and 3 (each within the scatter of the next).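

In this assay, chloro in place of methoxy on the aromatic carbon para to a large group gives a 1.2-fold lower number from compound 3 to compound 4 (0.09 log units; within the scatter), and chloro in place of hydrogen on that carbon gives a 1.2-fold lower number from compound 2 to compound 4 (0.06 log units; within the scatter), so this position now has three substituents with no separation beyond the scatter. Replacing ethoxy on the carbonyl carbon with (4-chlorophenyl)amino gives a 1.2-fold lower number from compound 1 to compound 4 (0.08 log units; within the scatter), which extends the same flat picture to a chloro-bearing amide. No supporting data bear on why these steps stay so small.

As far as these compounds go, whether an amine or a carboxylic acid on this aromatic carbon would give a step beyond the scatter remains open. The same holds for a longer chain in place of ethoxy on the carbonyl carbon.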